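The source may hold more compounds than are shown below. What is called first, only, known or untested is meant among the compounds shown, and "the series" means these compounds.

Measured so far in a functional assay on MCF7 cells (Homo sapiens) for inhibition, read by sulforhodamine B assay; a lower number here means a stronger inhibitor, a higher number a weaker inhibitor: compound 1 `Cc1ccc(NC2=CC(=O)c3c(nc4n3[C@H]3OC[C@@H](O)[C@H]3OC4)C2=O)cc1C` gives 4950 nM. Compound 2 `O=C1C(NC2CCCC2)=CC(=O)c2c1nc1n2[C@H]2OC[C@@H](O)[C@H]2OC1` gives > 16000 nM, which is a limit of the assay rather than a number. Compound 3 `O=C1C(NCc2ccccc2)=CC(=O)c2c1nc1n2[C@H]2OC[C@@H](O)[C@H]2OC1` gives > 8000 nM, likewise a limit of the assay.

Compound 3 therefore stands only at a limit in this assay, with no number of its own. Compound 4 `CCCN(CCC)C1=CC(=O)c2c(nc3n2[C@H]2OC[C@@H](O)[C@H]2OC3)C1=O` differs from it by dipropylamino in place of benzylamino on a double-bonded ring carbon. Among the compounds with values here, two measured steps bear on this: an at least 1.6-fold higher number from compound 1 to compound 3 (0.20 log units; that floor lies within the scatter) and an at least 3.2-fold higher number from compound 1 to compound 2 (0.50 log units; beyond the scatter), while a step that the two limits leave unreadable from compound 2 to compound 3. Given an at least 3.2-fold higher number from compound 1 to compound 2 (0.50 log units; beyond the scatter) and the limit already reached by compound 3, no strengthening is expected, and the step is estimated as a step that the limit leaves unreadable from compound 3 to compound 4. Compound 4 is thus expected to give 12000 nM in this assay, within 4000 nM to 40000 nM, most probably again as a limit.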

Compound 4, half-maximal inhibitory concentration: > 16000 nM
Compound 4: a limit, no number; the forecaster's own chance of this, stated with the estimate: 65%; middle value at least 1.3-fold (0.12 log units) from the limit.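

In this assay compound 4, whose dipropylamino group has no hydrogen-bond donor and no ring, gives > 16000 nM, a limit of the assay and not a number. In place of (3,4-dimethylphenyl)amino on the double-bonded ring carbon, dipropylamino gives an at least 3.2-fold higher number from compound 1 to compound 4 (0.50 log units; beyond the scatter). The steps joining compound 4 to compound 2 and compound 3 cannot be read, because each pair consists of limits: the limit of > 16000 nM in this assay, at which 2 of the 4 values shown sit.

From the compounds shown here alone, whether a simple phenylamino or a 4-methoxyphenylamino group would also give a number at this carbon stays open. So does the effect of a morpholine ring here.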